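Compound 4: a substituted phenyl on a series at the limit

The compounds below may be only part of what the source reports. "The series", "measured", "known", "first", "only" and "open" are said of these compounds alone.

Measured so far in an ADME assay on microsomes from liver (Mus musculus) for metabolic stability, read by LC-MS, with NADPH named in the record, with a stated time of 60 min, tested at 1 uM, in the absence of a further agent; on this read-out lower numbers stand for a less stable compound and higher numbers for a more stable compound

Compound 1 `COc1ccc(-c2c(C)sc3c(N4CC[C@@H](NC(C)=O)C4)nc(C)nc23)cc1OC` gives > 95%
Compound 2 `CC(=O)N[C@@H]1CCN(c2cc(C)nn3c(-c4ccccc4)c(C)nc23)C1` gives > 95%
Compound 3 `COc1cc(-c2c(C)nc3c(N4CC[C@@H](NC(C)=O)C4)cc(C)nn23)cc(OC)c1OC` gives > 95%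

Compound 2 stands at > 95% on the read-out of percent remaining, and that is a limit of the assay, not a number. Going by the values given here, the other two entries are limits as well, so the whole set comes down to one line (the limit of > 95% in this assay, at which 3 of the 3 values shown sit) and no measured compound can be ranked against another.

Compound 4 `COc1cc(-c2c(C)nc3c(N4CC[C@@H](NC(C)=O)C4)cc(C)nn23)ccc1F` has not been measured yet. It is compound 2 with 4-fluoro-3-methoxyphenyl in place of phenyl on an aromatic carbon. Among the compounds with values here, no step between measured compounds is available to size this change directly, so the closest guide is a single comparison. Compound 3 carries methoxy groups on its phenyl ring and gives > 95% as its result, which is again a limit.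

On that showing, the expectation in this assay is no change beyond the usual scatter. Any move is expected to be small and downward (a number at least 2 percentage points lower from compound 2 to compound 4 (that floor lies within the scatter)). For compound 4 the expected value is 93% with an estimated range from 78% to 100% in this measurement.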

Compound 4, percent of the compound remaining: > 95%
Compound 4: a limit, no number (the forecaster's own chance of this, stated with the estimate: 55%); at least 2 percentage points between middle value and limit.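

In this assay compound 4 gives > 95%, which is a limit of the assay and not a number. Compound 2 also stands at a limit, so no step can be read between compound 2 and compound 4: the limit of > 95% in this assay, at which 4 of the 4 values shown sit.

The compounds shown leave open whether 4-fluoro-3-methoxyphenyl in place of phenyl changes the percent of compound remaining at all.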